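Quinolin-3-yl replacing chlorothiophenyl in the benzylamine series

The compounds below may be only part of what the source reports. "The series", "measured", "known", "first", "only" and "open" are said of these compounds alone.

Measured compounds in an in vitro assay on CHOK cells for displacement of a labelled ligand from growth hormone secretagogue receptor type 1 (Homo sapiens); a higher number here means a weaker inhibitor, a lower number a stronger inhibitor:
compound 1 `Nc1nc(N)c(-c2ccc(NCc3ccc([N+](=O)[O-])cc3)cc2)c(COCc2ccccc2)n1` gives 0.2 nM;
compound 2 `Nc1nc(N)c(-c2ccc(NCc3ccnc(Cl)c3)cc2)c(COCc2ccccc2)n1` gives 1.5 nM;
compound 3 `Nc1nc(N)c(-c2ccc(NCc3csc(Cl)c3)cc2)c(COCc2ccccc2)n1` gives 6.3 nM.

Compound 3 holds the highest number of the three in this assay, with the weakest binding: the step from the nitro-substituted compound is a 32-fold higher number from compound 1 to compound 3 (1.50 log units; beyond the scatter), and from the pyridine compound it is a 4.2-fold higher number from compound 2 to compound 3 (0.62 log units; beyond the scatter). Both steps lie beyond the scatter, so the five-membered ring stands clearly apart from the two six-membered aromatic groups.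

Compound 4 `Nc1nc(N)c(-c2ccc(NCc3cnc4ccccc4c3)cc2)c(COCc2ccccc2)n1` carries quinolin-3-yl in place of 5-chlorothiophen-3-yl on a saturated chain carbon bound to a nitrogen on an aromatic ring. The change in the same position from compound 2 to compound 3 is the nearest measured step; it moved the number upward when a six-membered nitrogen-containing ring was replaced by the chlorothiophene, and the step from compound 1 to compound 3 pointed the same way. The present step reverses that direction, returning to a six-membered aromatic ring with one nitrogen, now fused to a further six-membered carbon ring. A step of the size seen for a 4.2-fold higher number from compound 2 to compound 3 (0.62 log units; beyond the scatter) in the opposite direction, to a lower number, is the expectation, written as a 4.2-fold lower number from compound 3 to compound 4 (0.62 log units; beyond the scatter). For compound 4 the estimate in this assay is 1.5 nM, ranging from 0.3 nM to 8 nM.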

Compound 4, half-maximal inhibitory concentration: 130 nM
For compound 4 the middle estimate is 87-fold (1.94 log units) below the measured one; measured number above the stated range.
By their numbers in this assay, from the lowest: compound 1; then compound 2; then compound 3; then compound 4.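

In this assay, compound 4 is the weakest of the four, with a 21-fold higher number from compound 3 to compound 4 (1.31 log units; beyond the scatter), an 87-fold higher number from compound 2 to compound 4 (1.94 log units; beyond the scatter) and a 650-fold higher number from compound 1 to compound 4 (2.81 log units; beyond the scatter), all beyond the scatter. A six-membered aromatic ring with one nitrogen on the saturated chain carbon therefore does not by itself give a low number, and ring size alone no longer sorts the series, since compound 3, with its five-membered ring, falls between compound 2 and compound 4. No measurement at hand accounts for this step.

The compounds shown leave open whether the second, fused ring or the different attachment of the nitrogen-containing ring goes with the higher number; a pyridin-3-yl group and a naphthalen-2-yl group at this place would separate the two. Also open, as far as these compounds go, is how a fused ring carrying a chlorine or a nitro group would read here.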